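The source may hold more compounds than are shown below. What is called first, only, known or untested is meant among the compounds shown, and "the series" means these compounds.

Measured in a physicochemical assay for solubility, in phosphate buffer; a lower number here means a less soluble compound, a higher number a more soluble compound:
- compound 1 `Cc1cc(N2CCc3nnn(Cc4ccc5ncccc5c4)c3C2=O)sn1`: 2.2 ug/mL
- compound 2 `Cc1cc(-n2ccc3nnn(Cc4ccc5ncccc5c4)c3c2=O)sn1`: < 1 ug/mL (a limit of the assay, not a number)

Compound 2 has no exact reading, only the limit < 1 ug/mL. From the compounds shown here alone, it therefore stands at the limit of < 1 ug/mL in this assay, at which 1 of the 2 values shown sits, and its true position is unknown. Among the measured compounds shown here, compound 1 is the only one of the pair with a number.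

Compound 3 `Cc1cc(-n2ccc3nnn([C@@H](C)c4ccc5ncccc5c4)c3c2=O)sn1` keeps the core of compound 2 and carries methyl in place of hydrogen on a saturated chain carbon bound to an aromatic carbon and an aromatic nitrogen. For the measured compounds named here, no measured pair shows this change, so the expectation is cautious. The expected step of a number no lower from compound 2 to compound 3 (the limit leaves the size open) is estimated to stay within the usual scatter, with no direction favoured. A reading reported only as a limit is quite possible. The estimate for compound 3 is 1 ug/mL, with an expected range of 0.4 ug/mL to 3 ug/mL.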

Compound 3, solubility: 4.5 ug/mL
Compound 3: the middle estimate sits 4.5-fold (0.65 log units) below what was measured; the whole stated range lies below it.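

In this assay, the saturated chain carbon bound to an aromatic carbon and an aromatic nitrogen proves to be a position where a substituent can shift the reading: methyl in place of hydrogen gives an at least 4.5-fold higher number from compound 2 to compound 3 (0.65 log units; beyond the scatter). Compound 2 reads < 1 ug/mL, which is a limit of the assay and not a number. The step is therefore a lower bound whose true size stays unknown, with its lower end resting on: the limit of < 1 ug/mL in this assay, at which 1 of the 3 values shown sits.

Open, from the compounds shown here alone, is whether the step belongs to methyl alone or also extends to a longer chain such as ethyl, or to an aminomethyl group, on this carbon. Also open, going by these compounds, are the mirror-image form of compound 3 and whether methyl at this place on the core of compound 1 would give a comparable step.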